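Fluoro to hydrogen on the aryl ketone of compound 1

This account rests on a few compounds, and the source may have more. Where it says the series, first, only, none or still open, it means among the compounds named here.

Compound 1 `CCOC(=O)c1[nH]c(=O)c(C#N)cc1C(=O)c1ccc(F)cc1` gives 232000 nM in an ADME assay on L929 cells (Mus musculus) for cytotoxicity, read by MTT assay, with a stated time of 72 h (a higher number here means that more compound is tolerated, a lower number that less compound is tolerated), the lowest of the three numbers in hand. Compound 3 `CCOC(=O)c1[nH]c(=O)c(C#N)cc1C(=O)c1ccc(Br)cc1` gives 242000 nM, and compound 2 `O=C(c1ccc([N+](=O)[O-])cc1)c1cc(C(=O)O)c(=O)[nH]c1C(=O)O` gives 439000 nM; both lie within the scatter of compound 1. Compound 4 `CCOC(=O)c1[nH]c(=O)c(C#N)cc1C(=O)c1ccccc1` carries hydrogen in place of fluoro on an aromatic carbon. Among the compounds with values here, the only measured step that touches this aromatic carbon is a 1.0-fold higher number from compound 1 to compound 3 (0.02 log units; within the scatter), so swapping one group for another there left the number unchanged. Within the data shown here, no step shows what removing the group altogether does, but with compound 3 at 242000 nM no step beyond the scatter is expected for compound 4. The estimated step is a 1.0-fold lower number from compound 1 to compound 4 (0.00 log units; within the scatter). Compound 4 is expected to give 230000 nM, between 115000 nM and 460000 nM.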

Compound 4, half-maximal cytotoxic concentration: 465000 nM
The estimate for compound 4 lay 2.0-fold (0.31 log units) below the measured number; the measured number lies above the stated range.
By their numbers in this assay, from the lowest: compounds 1, 3, 2 and 4 (each within the scatter of the next).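

Taking the halogen off this aromatic carbon altogether gives, in this assay, a 2.0-fold higher number from compound 1 to compound 4 (0.30 log units; within the scatter) and a 1.9-fold higher number from compound 3 to compound 4 (0.28 log units; within the scatter), so the step stays within the scatter even with no halogen present. Fluoro, bromo and hydrogen at this place, para to a large group, are therefore not told apart by this read-out. Nothing available bears on what lies behind these numbers.

The compounds shown leave open whether an amine or a methoxy group on this carbon would give a step beyond the scatter. They also leave open whether a longer chain in place of the ethyl ester would do so.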